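Nitro to fluoro on the phenol ring of the imine series

This account rests on a few compounds, and the source may have more. Where it says the series, first, only, none or still open, it means among the compounds named here.

Three imines sharing one core have been run in an assay on isolated protein for inhibition of Amine oxidase [flavin-containing] B (Homo sapiens), read by fluorescence and Amplex Red, with stated times of 15 min and 20 min; on this read-out lower numbers stand for stronger inhibition and higher numbers for weaker inhibition. Compound 1 `O=[N+]([O-])c1ccc(O)c(/C=N/c2ccc(OCc3ccccc3)cc2)c1` gives 60900 nM, the highest of the three numbers. Compound 2 `COc1ccc(/C=N/c2ccc(OCc3ccccc3)cc2)c(O)c1` gives 23600 nM, the nearest to compound 1 and still beyond the scatter from it. Compound 3 `Oc1c(Br)cc(Br)cc1/C=N/c1ccc(OCc2ccccc2)cc1` gives 10800 nM, the furthest from compound 1 and well beyond the scatter. Going by the values given here, no pair of these three differs in only one place, so no single-change step can be read from them; the numbers merely show that compound 1 sits at the weak end of what has been measured.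

Compound 4 `Oc1ccc(F)cc1/C=N/c1ccc(OCc2ccccc2)cc1` is the next member and is not yet measured. Relative to compound 1 the change is fluoro in place of nitro on an aromatic carbon; fluoro in place of nitro on an aromatic carbon. With nothing on this substitution among the measured compounds, the expectation rests on the range the other two members define. The expected step is a 2.4-fold lower number from compound 1 to compound 4 (0.39 log units; beyond the scatter). In this assay compound 4 is therefore estimated at 25000 nM, with a range from 8000 nM to 80000 nM.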

Compound 4, half-maximal inhibitory concentration: 15300 nM
Beside the measured number, compound 4's estimate is 1.6-fold (0.21 log units) above it; measured number inside the range.
By their numbers in this assay, from the lowest: compounds 3, 4 and 2 (each within the scatter of the next, the first and the last beyond it); then compound 1.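

Going by these compounds alone, this is the only single-change step so far: on the aromatic carbon para to a hydroxy group and meta to a large group, fluoro in place of nitro gives a 4.0-fold lower number from compound 1 to compound 4 (0.60 log units; beyond the scatter) in this assay, so the substituent at this position alone moves the number beyond the scatter, though only modestly. The change swaps nitro, with its three heavy atoms and two hydrogen-bond acceptors, for fluoro, with one heavy atom and no hydrogen-bond acceptors, so this single step varies group size and acceptor count together and cannot separate them. No measurement shown here bears on why the number falls with this change.

Still open, as far as these compounds go, is whether the step follows the loss of nitro or the arrival of fluoro, which plain hydrogen at the same position would help to settle. Chloro, a nitrile or an amine on this carbon, with the rest of the core of compound 4 unchanged, would show whether other groups here move the number further in either direction.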